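The compounds below may be only part of what the source reports. "The series", "measured", "known", "first", "only" and "open" are said of these compounds alone.

In a functional assay on HepG2 cells (Homo sapiens) for antiproliferative activity, read by MTT assay (a lower number here means a stronger inhibitor, a higher number a weaker inhibitor), compound 1 (`Cc1cccc(Nc2nccc(-c3ccc(Br)cc3)n2)c1`) gives 74600 nM, within the scatter of compound 2 (`Clc1ccc(Nc2nccc(-c3ccc(Br)cc3)n2)cc1`) at 47500 nM. Compound 3 (`COc1cccc(Nc2nccc(-c3ccc(Br)cc3)n2)c1`) has methoxy in place of methyl on an aromatic carbon, meta to a large group: methoxy in place of methyl on an aromatic carbon. For the measured compounds named here, the one measured step, a 1.6-fold lower number from compound 1 to compound 2 (0.20 log units; within the scatter), replaces the 3-methylphenyl of compound 1 with 4-chlorophenyl and is the only guide available. On that evidence, no step beyond the scatter is expected in this assay. For compound 3 the estimated value is 60000 nM, with an expected range of 25000 nM to 130000 nM. The estimated step is a 1.2-fold lower number from compound 1 to compound 3 (0.09 log units; within the scatter).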

Compound 3, half-maximal inhibitory concentration: 148000 nM
The estimate for compound 3 lay 2.5-fold (0.39 log units) below the measured number; measured number outside the range, above it.
By their numbers in this assay, from the lowest: compounds 2, 1 and 3 (each within the scatter of the next, the first and the last beyond it).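

In this assay, methoxy in place of methyl on an aromatic carbon, meta to a large group, gives a 2.0-fold higher number from compound 1 to compound 3 (0.30 log units; within the scatter). For the compounds shown here, this is the first reading of a change at this position alone, and it shows that one added oxygen and one hydrogen-bond acceptor here leave compound 3 within the scatter of compound 1. No measured property bears on this result.

Still open, going by these compounds, is whether a longer chain such as butoxy, an amine or a carboxylic acid on this carbon would give a step beyond the scatter. The compounds shown also leave open how methoxy would read on the other carbons of this ring.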